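The source may hold more compounds than are shown below. What is called first, only, known or untested is meant among the compounds shown, and "the series" means these compounds.

Three compounds sharing one core were measured in an assay on membranes from HEK293 cells for displacement of a labelled ligand from adenosine receptor A2b (Homo sapiens), read by scintillation counting, with a stated time of 30 min, tested at 1 uM; on this read-out higher numbers stand for more inhibition at the one concentration tested (going by the name of the read-out) and lower numbers for less inhibition. Compound 1 `CC1=C(C(=O)NC(C)C)C(c2ccco2)NC(=O)N1` gives 2% in this assay. Compound 2 `CC1=C(C(=O)NC(C)C)C(c2ccoc2)NC(=O)N1` gives 3% in this assay. The two differ in one place, (furan-3-yl in place of furan-2-yl on a saturated ring carbon), and the step is a number 1 percentage points higher from compound 1 to compound 2 (within the scatter). Compound 3 `CCC(CC)OC(=O)C1=C(C)NC(=O)NC1c1ccco1` gives 35% in this assay; the step from the isopropylamino compound is a number 33 percentage points higher from compound 1 to compound 3 (beyond the scatter), and compound 3 stands highest of the three, beyond the scatter from both compound 1 and compound 2.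

Compound 4 `CCC(CC)OC(=O)C1=C(C)NC(=O)NC1c1ccoc1` is not yet measured. It differs from compound 3 in one place, (furan-3-yl in place of furan-2-yl on a saturated ring carbon). This is the same kind of change as that from compound 1 to compound 2, though around the place the ring atom bears a group of 8 heavy atoms rather than an isopropylcarbamoyl group (6 heavy atoms); the two cores differ as follows: (pentan-3-yl)oxy in place of isopropylamino on a carbonyl carbon.

The step expected from compound 3 to compound 4 is a number 1 percentage points higher from compound 3 to compound 4 (within the scatter), resting on how small the step from compound 1 to compound 2 was, a number 1 percentage points higher from compound 1 to compound 2 (within the scatter). Compound 4 is therefore estimated at 36%, with a likely range from 20% to 52%.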

Compound 4, a percentage reported as inhibition, at one concentration (the size of the read-out at that concentration, not a potency): 28%
For compound 4 the middle estimate is 8 percentage points above the measured one, and the stated range covers the measured number.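

In this assay the furan-3-yl for furan-2-yl change stays within the scatter on the second core as well, with a number 7 percentage points lower from compound 3 to compound 4 (within the scatter), and its two readings agree: the same change on two cores in this assay, a number 1 percentage points higher (within the scatter) from compound 1 to compound 2 and a number 7 percentage points lower (within the scatter) from compound 3 to compound 4, 8 percentage points apart, within the scatter of two such steps. The (pentan-3-yl)oxy for isopropylamino change also carries across, now with a number 25 percentage points higher from compound 2 to compound 4 (beyond the scatter), so it holds with either furan attached: the same change on two cores in this assay, a number 33 percentage points higher (beyond the scatter) from compound 1 to compound 3 and a number 25 percentage points higher (beyond the scatter) from compound 2 to compound 4, 8 percentage points apart, within the scatter of two such steps. This agreement rests on four compounds tested at one concentration, so it gives no potency and does not show that either change would behave the same way on any other core.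

The compounds shown leave open how a phenyl or thiophen-2-yl ring would read in place of the furan, and whether a shorter or longer alkyl chain or a cyclohexyl group on the oxygen would raise or lower the number. They also leave open what an ethyl group or a larger chain would do in place of the methyl group on the ring.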